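This account rests on a few compounds, and the source may have more. Where it says the series, first, only, none or still open, it means among the compounds named here.

Compound 1 (`COc1ccc(-c2nc3ccccn3c2Sc2ccccc2)cc1`) is the starting point here. In an ADME assay on HEK293 cells (Homo sapiens) for inhibition, read by MTT assay, with a stated time of 48 h (on this read-out higher numbers stand for weaker inhibition and lower numbers for stronger inhibition), compound 1 gives > 100000 nM as its reading, and this is a limit of the assay, not a number. Compound 2 (`CS(=O)(=O)c1ccc(-c2nc3ccccn3c2Sc2cccc3ccccc23)cc1`) gives 83200 nM in this assay as an actual measured number. Compound 3 (`c1ccc(Sc2c(-c3ccsc3)nc3ccccn23)cc1`) carries thiophen-3-yl in place of 4-methoxyphenyl on an aromatic carbon of the shared core (thiophen-3-yl in place of 4-methoxyphenyl on an aromatic carbon) and keeps the phenylsulfanyl group. Going by the values given here, compound 1 offers no firm number because of the limit of > 100000 nM in this assay, at which 1 of the 2 values shown sits, and no measured pair shows this swap, so in this assay no step beyond the usual scatter is expected in either direction. The estimated change is a number no higher from compound 1 to compound 3 (the limit leaves the size open) and it is expected to stay small. Compound 3 is estimated at 100000 nM with an expected range from 50000 nM to 200000 nM and may well turn out to be only a limit.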

Compound 3, half-maximal inhibitory concentration: 91700 nM
Compound 3: middle estimate off by 1.1-fold (0.04 log units), on the high side; measured number inside the range.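

Thiophen-3-yl in place of 4-methoxyphenyl gives the first step that can be read at this position on the shared core: in this assay there is an at least 1.0-fold lower number from compound 1 to compound 3 (0.03 log units; that floor lies within the scatter). With this smaller five-membered aromatic ring on the same aromatic carbon and the phenylsulfanyl group kept, compound 3 gives an actual measured number, 91700 nM. The true size of the step stays unknown because only a floor can be stated for it: the limit of > 100000 nM in this assay, at which 1 of the 3 values shown sits.

From the compounds shown here alone, whether an amine or a carboxylic acid on this same carbon would shift the reading beyond the usual scatter remains open. Also open, going by these compounds, is how the reading responds when the phenylsulfanyl group alone gives way to a group such as a longer alkyl chain, with thiophen-3-yl held in place.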